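Removing the chloro group from compound 1

This account rests on a few compounds, and the source may have more. Where it says the series, first, only, none or still open, it means among the compounds named here.

Measured in a functional assay on DWD cells (Homo sapiens) for inhibition, read by sulforhodamine B assay; a lower number here means a stronger inhibitor of growth, a higher number a weaker inhibitor of growth:
- compound 1 `Cc1ccc2[nH]c(-c3ccc(-c4ccc(-c5cccc(Cl)c5)cc4)cc3)nc2c1`: 2510 nM
- compound 2 `COc1ccc(-c2ccc(-c3ccc(-c4nc5ccccc5[nH]4)cc3)cc2)cc1`: 100000 nM
- compound 3 `Clc1cccc(-c2ccc(-c3ccc(-c4nc5ccccc5[nH]4)cc3)cc2)c1`: 100000 nM

Compound 1 has the lowest number of the three, and the other two share the same value. The next compound, compound 4 `Cc1ccc2[nH]c(-c3ccc(-c4ccc(-c5ccccc5)cc4)cc3)nc2c1`, differs from compound 1 by hydrogen in place of chloro on an aromatic carbon, with hydrogen in place of chloro on an aromatic carbon, meta to a large group.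

Among the measured compounds shown here, two measured steps bear on this. The only one that alters the 3-chlorophenyl group is no change at the digits printed from compound 2 to compound 3 (within the scatter). Both of its compounds sit at the same high number, so it says little about a change made from the level of compound 1. The other, a 40-fold higher number from compound 1 to compound 3 (1.60 log units; beyond the scatter), is large, but it replaces methyl and leaves the chloro in place. For the measured compounds named here, no measured pair removes chloro alone.

A small rise in this assay is therefore expected, possibly none beyond the scatter. The expected change is a 1.6-fold higher number from compound 1 to compound 4 (0.20 log units; within the scatter). Compound 4 is estimated at 4000 nM, with an expected range of 1200 nM to 20000 nM.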

Compound 4, concentration for 50% growth inhibition: 28300 nM
Compound 4: middle estimate off by 7.1-fold (0.85 log units), on the low side; the whole stated range lies below it.
By their numbers in this assay, from the lowest: compound 1; then compound 4; then compounds 2 and 3 (each within the scatter of the next).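

In this assay, the change from 3-chlorophenyl to phenyl gives an 11-fold higher number from compound 1 to compound 4 (1.05 log units; beyond the scatter), so the chloro counts for a large part of the growth inhibition seen with compound 1. The earlier step that altered this aryl group started from a value of compound 2 that matched compound 3, and so could not show this. Taking either the chloro or the methyl away from compound 1 now gives a large rise, with a 40-fold higher number from compound 1 to compound 3 (1.60 log units; beyond the scatter) for the methyl, and no measurement shown explains the effect of the chloro.

As far as these compounds go, whether a bromo, a trifluoromethyl or an amine on the same carbon could replace the chloro remains open. Also open, from the compounds shown here alone, is whether the chloro has any effect on the core that lacks the methyl.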